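The source may hold more compounds than are shown below. What is called first, only, known or untested is meant among the compounds shown, and "the series" means these compounds.

Two compounds share one core, and a third is built on it as well. Compound 1 `CC(=O)c1cccc(NC(=O)CSc2nc3cccnc3[nH]2)c1` gives 50% in an assay on isolated protein for inhibition of Ectonucleotide pyrophosphatase/phosphodiesterase family member 1 (Homo sapiens), tested at 10 uM; a lower number here means less inhibition, a higher number more inhibition at the concentration tested (going by the name of the read-out). Compound 2 `COc1ccc(NC(=O)CSc2nc3cccnc3[nH]2)cc1` gives 48% in this assay, a number within the usual scatter of that of compound 1, so the two cannot be told apart. Compound 3 `N#Cc1cccc(NC(=O)CSc2nc3cccnc3[nH]2)c1` has not yet been measured in this assay. It differs from compound 1 in one place: cyano in place of acetyl on an aromatic carbon. Within the data shown here, no measured pair shows how such a swap plays out here, so only a small change is expected, a number 5 percentage points lower from compound 1 to compound 3 (within the scatter). Compound 3 is thus expected to give about 45%, between 25% and 65%.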

Compound 3, a percentage reported as inhibition, at one concentration (the size of the read-out at that concentration, not a potency): 45%
For compound 3 middle estimate and measured number coincide at the digits printed; measured number inside the range.
By their numbers in this assay, from the lowest: compounds 3, 2 and 1 (each within the scatter of the next).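

In this assay, cyano in place of acetyl on this aromatic carbon gives a number 5 percentage points lower from compound 1 to compound 3 (within the scatter), so the two groups cannot be told apart at this position. Both count one hydrogen-bond acceptor and no donor, so this pair cannot show whether an acceptor at this place matters. No measurement shown offers a reason for this result. An amine or a carboxylic acid on this carbon could still shift the number in either direction. Going by these compounds, whether a longer chain here would keep the inhibition also remains open.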